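Diethylamino propenoyl amide in place of the dimethylpropenoyl amide

The source may report more compounds than this note shows. Statements on the series, on what has been measured and on what is new or still open speak of the compounds shown alone.

Compound 1 `COc1cc2ncnc(N3CCCc4ccccc43)c2cc1NC(=O)C=C(C)C` gives 6130 nM in a functional assay on PC-3 cells (Homo sapiens) for antiproliferative activity, read by MTT assay, with a stated time of 72 h (a higher number here means a weaker inhibitor, a lower number a stronger inhibitor), the second highest of the three numbers. Compound 2 `CC(C)=CC(=O)Nc1cc2c(N3CCCc4ccccc43)ncnc2cc1O[C@@H]1CCOC1` gives 9020 nM; the step of a 1.5-fold higher number from compound 1 to compound 2 (0.17 log units; within the scatter) stays within the scatter. Compound 3 `O=C(/C=C/CN1CCCC1)Nc1cc2c(N3CCc4ccccc43)ncnc2cc1O[C@@H]1CCOC1` gives 1510 nM, the lowest number, but it differs from compound 1 in several places, so no single step can be read from it. Compound 4 `CCN(CC)C/C=C/C(=O)Nc1cc2c(N3CCCc4ccccc43)ncnc2cc1OC` carries 3-(diethylamino)prop-1-en-1-yl in place of 2-methylprop-1-en-1-yl on a carbonyl carbon. For the measured compounds named here, no measured step covers this change on its own; compound 3, the only measured compound with an amine on the acrylamide chain, shows the lower number, and that is the only pointer. The expected step is a 3.1-fold lower number from compound 1 to compound 4 (0.49 log units; beyond the scatter), toward a lower number, with wide uncertainty. Compound 4 is estimated at 2000 nM, range 700 nM to 6000 nM.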

Compound 4, half-maximal inhibitory concentration: 6890 nM
Beside the measured number, compound 4's estimate is 3.4-fold (0.54 log units) below it; the measured number lies above the stated range.
By their numbers in this assay, from the lowest: compound 3; then compounds 1, 4 and 2 (each within the scatter of the next).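

In this assay, for the compounds shown here, the step of a 1.1-fold higher number from compound 1 to compound 4 (0.05 log units; within the scatter) is the first single change read at this carbonyl carbon, and it replaces 2-methylprop-1-en-1-yl with 3-(diethylamino)prop-1-en-1-yl. On the core of compound 1, this position therefore accepts the larger chain with its added nitrogen without a change in the number beyond the scatter. No measurement available here explains this result.

Still open, going by these compounds, is whether a morpholine or a dimethylamino group at the end of this chain would shift the number on this core. On these data alone, a longer chain carrying the diethylamino group is equally open.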